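Removing the hydroxymethyl from a nucleoside thioether side chain

A few compounds are considered here, and "the series" means these few. Any claim that something is new, unique, unknown or untested is made for them only; others in the source may bear on it.

Measured compounds:
compound 1, `OC[C@H]1O[C@@H](n2cnc3c(COc4ccccn4)ncnc32)[C@H](O)[C@@H]1O`, > 250000 nM
compound 2, `OC[C@H]1O[C@@H](n2cnc3c(CSc4ccccn4)ncnc32)[C@H](O)[C@@H]1O`, > 100000 nM
compound 3, `OCCSCc1ncnc2c1ncn2[C@@H]1O[C@H](CO)[C@@H](O)[C@H]1O`, > 100000 nM

In a functional assay on Huh-7 cells (Homo sapiens) for cytotoxicity, read by MTT assay, with a stated time of 3 days (on this read-out higher numbers stand for lower toxicity in this test and lower numbers for higher toxicity in this test), compound 3 gives > 100000 nM, and that value is a limit of the assay rather than a number. Compound 1 likewise gives only a limit, > 250000 nM. Compound 2 also gives only a limit, > 100000 nM. Two of the three values sit at the limit of > 100000 nM in this assay, at which 2 of the 3 values shown sit, and the remaining one at the limit of > 250000 nM in this assay, at which 1 of the 3 values shown sits. Going by the values given here, the steps a step that the two limits leave unreadable from compound 1 to compound 2, a step that the two limits leave unreadable from compound 1 to compound 3 and a step that the two limits leave unreadable from compound 2 to compound 3 therefore have no readable size, so no measured step speaks for or against a change in this assay.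

Compound 4, `CSCc1ncnc2c1ncn2[C@@H]1O[C@H](CO)[C@@H](O)[C@H]1O`, is not yet measured. It differs from compound 3 by hydrogen in place of hydroxymethyl on a saturated chain carbon bound to a sulfur. Among the compounds with values here, none of the measured steps bears on this change with a readable size; all three compounds so far sit at a limit. Compound 4 is therefore expected to behave like compound 3, with a number no higher from compound 3 to compound 4 (the limit leaves the size open) representing no step beyond the scatter, and most likely a limit again. The estimate for compound 4 in this assay is 100000 nM, within a range from 50000 nM to 300000 nM.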

Compound 4, half-maximal cytotoxic concentration: > 100000 nM
Compound 4 gave a limit, no number; the forecaster's own chance of this, stated with the estimate: 85%; the middle value lies on the limit itself.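

In this assay, going by these compounds alone, compound 4 gives > 100000 nM, a limit of the assay and not a number, so no step between compound 4 and compound 1, compound 2 or compound 3 can be read. The compounds shown leave open whether replacing hydroxymethyl with hydrogen on a saturated chain carbon bound to a sulfur changes cytotoxicity at all.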